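Trimethoxyphenyl benzimidazoles: aryl group change toward a 3-aminophenyl

The compounds below may be only part of what the source reports. "The series", "measured", "known", "first", "only" and "open" are said of these compounds alone.

The shared core carries a trimethoxyphenyl on the imidazole nitrogen and a varied aryl group on the fused ring. Compound 1 `COc1cc(-n2cnc3ccc(-c4ccccc4Cl)cc32)cc(OC)c1OC` gives in a functional assay on MCF7 cells (Homo sapiens) for antiproliferative activity, read by MTT assay, with a stated time of 72 h (on this read-out lower numbers stand for stronger inhibition and higher numbers for weaker inhibition), only a limit, > 10000 nM (the limit of > 10000 nM in this assay, at which 1 of the 3 values shown sits). Compound 2 `COc1cc(-n2cnc3ccc(-c4ccc(C(C)=O)cc4)cc32)cc(OC)c1OC` gives 1540 nM and compound 3 `COc1cc(-n2cnc3ccc(-c4ccc([N+](=O)[O-])cc4)cc32)cc(OC)c1OC` gives 740 nM. Among the two numbers, compound 2 stands highest; its nearest neighbour is compound 3, reached by a 2.1-fold lower number from compound 2 to compound 3 (0.32 log units; beyond the scatter). Replacing the 2-chlorophenyl of compound 1 gives an at least 6.4-fold lower number from compound 1 to compound 2 (0.81 log units; beyond the scatter) and an at least 13-fold lower number from compound 1 to compound 3 (1.13 log units; beyond the scatter).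

Compound 4 `COc1cc(-n2cnc3ccc(-c4cccc(N)c4)cc32)cc(OC)c1OC` is not yet measured. It differs from compound 2 by 3-aminophenyl in place of 4-acetylphenyl on an aromatic carbon. For the measured compounds named here, no measured step exchanges a 4-substituted phenyl for a 3-substituted one, nor removes the carbonyl of the acetyl; both measured steps that gave lower numbers kept a group on the 4-position. The step from compound 2 to compound 4 is therefore expected to be small to modest toward a higher number, a 1.6-fold higher number from compound 2 to compound 4 (0.21 log units; within the scatter). Compound 4 is expected to give about 2500 nM, within 700 nM to 9000 nM.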

Compound 4, half-maximal inhibitory concentration: 180 nM
The estimate for compound 4 lay 14-fold (1.14 log units) above the measured number; the measured number lies below the stated range.
By their numbers in this assay, from the lowest: compound 4; then compound 3; then compound 2. At a limit, above all of these: compound 1.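

An aryl group without a substituent on its 4-position can still give a low number at this place on the shared core: in this assay, the 3-aminophenyl gives an 8.6-fold lower number from compound 2 to compound 4 (0.93 log units; beyond the scatter) and a 4.1-fold lower number from compound 3 to compound 4 (0.61 log units; beyond the scatter), which makes compound 4 the lowest of the series. The 3-aminophenyl, the only aryl group shown with a hydrogen-bond donor, also gives an at least 55-fold lower number from compound 1 to compound 4 (1.74 log units; beyond the scatter). The value of compound 1 in that comparison is a limit: the limit of > 10000 nM in this assay, at which 1 of the 4 values shown sits.

Each step to compound 4 changes both the group and where it sits on the phenyl ring, so the contribution of each remains unresolved. A 4-aminophenyl and a 3-nitrophenyl would separate the two, while an N-methylamino or acetamido group on the same ring would test how much of the amine is needed.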